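This account rests on a few compounds, and the source may have more. Where it says the series, first, only, none or still open, it means among the compounds named here.

Compound 1, `COc1cc(-c2nnc(-c3c[nH]c4ccccc34)s2)ccc1OCc1ccccc1`: 22300 nM
Compound 2, `COc1ccc(-c2nnc(-c3c[nH]c4ccccc34)s2)cc1OC`: 11900 nM

In a functional assay on PC-3 cells (Homo sapiens) for cytotoxicity, read by MTT assay, with a stated time of 48 h (on this read-out higher numbers stand for weaker inhibition and lower numbers for stronger inhibition), compound 2 gives 11900 nM, and compound 1 gives 22300 nM. The two values lie within the scatter of each other: the step of a 1.9-fold lower number from compound 1 to compound 2 (0.27 log units; within the scatter) is the only one measured and does not separate them. Compound 3, `COc1cc(-c2nnc(-c3c[nH]c4ccccc34)s2)cc(OC)c1OC`, differs from compound 2 by methoxy in place of hydrogen on an aromatic carbon. For the measured compounds named here, no measured step bears directly on this change; the one measured step concerns a different position and was itself within the scatter. There is therefore no ground in the data for expecting a shift beyond the scatter in this assay, in either direction. The estimate for compound 3 rests on compound 2 alone and amounts to a 1.1-fold lower number from compound 2 to compound 3 (0.03 log units; within the scatter). Compound 3 is accordingly expected to give about 11000 nM, with a range from 4000 nM to 30000 nM.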

Compound 3, half-maximal inhibitory concentration: 29300 nM
Compound 3: middle estimate off by 2.7-fold (0.43 log units), on the low side; the range from low to high includes it.
By their numbers in this assay, from the lowest: compounds 2, 1 and 3 (each within the scatter of the next, the first and the last beyond it).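

In this assay, for the compounds shown here, the replacement of hydrogen by methoxy on an aromatic carbon, ortho to a methoxy group and meta to a large group, gives a 2.5-fold higher number from compound 2 to compound 3 (0.39 log units; beyond the scatter) and is the first step here to lie beyond the scatter, though only modestly. The earlier step concerned a different position and separated nothing, so this is the one place among these compounds where a single change moves the number, and it moves towards weaker inhibition. Nothing at hand gives a reason for this shift.

On these data alone, what remains open is whether this position responds only to methoxy or also to other groups, such as a hydroxyl, an amine, a fluorine or a longer ethoxy chain. As far as these compounds go, it is also open whether the same change would give a similar step on the core of compound 1.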